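Swapping the halogen on the exocyclic carbon of a brominated lactone

A few compounds are considered here, and "the series" means these few. Any claim that something is new, unique, unknown or untested is made for them only; others in the source may bear on it.

This account concerns a small set of halogenated butenolides tested in a functional assay on KB cells (Homo sapiens) for cytotoxicity; on this read-out lower numbers stand for an effect already at smaller amounts and higher numbers for an effect only at larger amounts of compound. Compound 1 `CCCCC1=C(Br)/C(=C/Br)OC1=O` carries no hydroxyl on its side chain; in this assay compound 1 reaches only the limit > 20 ug/mL, which is a limit of the assay and not a number, as recorded in the limit of > 20 ug/mL in this assay, at which 1 of the 3 values shown sits. Compound 2 `CCC[C@@H](O)C1=C(Br)/C(=C\Br)OC1=O` bears a hydroxylated side chain and gives 1.1 ug/mL in this assay. Compound 3 `CCC[C@@H](O)C1=C(Br)/C(=C/I)OC1=O` gives 0.3 ug/mL in this assay, the lowest of the two numbers shown, with compound 2 as its nearest neighbour at a distance beyond the usual scatter.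

Compound 4 `CCC[C@@H](O)C1=C(Br)/C(=C/Br)OC1=O` has not yet been measured. It differs from compound 3 in one place: bromo in place of iodo on a double-bonded chain carbon bound to a double-bonded ring carbon. Among the measured compounds shown here, no step between measured compounds tells what this exchange does here, so the expectation rests on the values of compound 2 and compound 3 alone. Compound 4 is estimated at 0.9 ug/mL in this assay, within 0.3 ug/mL to 2.5 ug/mL, the expected step being a 3.0-fold higher number from compound 3 to compound 4 (0.48 log units; beyond the scatter).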

Compound 4, concentration for half-maximal effect: 0.1 ug/mL
Compound 4: middle estimate off by 9.0-fold (0.95 log units), on the high side, outside the stated range (below it).
By their numbers in this assay, from the lowest: compound 4; then compound 3; then compound 2. At a limit, above all of these: compound 1.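

In this assay, bromo in place of iodo on a double-bonded chain carbon bound to a double-bonded ring carbon gives a 3.0-fold lower number from compound 3 to compound 4 (0.48 log units; beyond the scatter), so at this place the exchange of iodo for bromo moves toward smaller amounts, and iodo is not needed for the effect. The configuration of the double bond carries a large step of its own, an 11-fold lower number from compound 2 to compound 4 (1.04 log units; beyond the scatter), with no change of atoms: the fact that compounds 2 and 4 differ only in the configuration as drawn. Hydroxy in place of hydrogen on a saturated chain carbon bound to a double-bonded ring carbon and a saturated chain carbon gives an at least 200-fold lower number from compound 1 to compound 4 (2.30 log units; beyond the scatter), a step that rests on a limit and not on a number: the limit of > 20 ug/mL in this assay, at which 1 of the 4 values shown sits.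

The compounds shown leave open what chloro would give on the same carbon. They also leave open whether an amine in place of the hydroxy, or a longer chain, would keep these values.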